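The compounds below may be only part of what the source reports. "The series", "measured", "known", "first", "only" and "open" are said of these compounds alone.

Compound 1, `CCCS(=O)(=O)Nc1ccc(Cl)c(C(=O)Nc2cnc3[nH]nc(OC)c3c2)c1F`: 0.11 L/kg
Compound 2, `CCCS(=O)(=O)Nc1ccc(F)c(C(=O)Nc2cnc3[nH]cc(Br)c3c2)c1F`: 0.24 L/kg

Both compounds were run in an in vivo ADME assay on the whole organism (strain CD-1) for pharmacokinetics, with Mus musculus as the target; on this read-out lower numbers stand for narrower distribution and higher numbers for wider distribution into tissues. On these two numbers compound 1 stands lowest; its nearest neighbour is compound 2, whose number lies above it by a gap beyond the usual scatter. The two compounds differ in more than one place, so their values say nothing about any single change.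

Compound 3, `CCCS(=O)(=O)Nc1ccc(Cl)c(C(=O)Nc2cnc3[nH]ncc3c2)c1F`, differs from compound 1 in one place only: hydrogen in place of methoxy on an aromatic carbon. Among the compounds with values here, no measured pair shows this same change, so the expectation rests on compound 1 alone. The step from compound 1 to compound 3 is expected to stay within the scatter, with no clear direction, as a 1.2-fold higher number from compound 1 to compound 3 (0.07 log units; within the scatter). Compound 3 is therefore estimated at 0.13 L/kg in this assay, with a range from 0.07 L/kg to 0.25 L/kg.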

Compound 3, volume of distribution in the Mus musculus assay: 0.17 L/kg
Compound 3: middle estimate off by 1.3-fold (0.12 log units), on the low side; low and high end bracket the measured number.
By their numbers in the Mus musculus assay, from the lowest: compounds 1, 3 and 2 (each within the scatter of the next, the first and the last beyond it).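

In the Mus musculus assay, hydrogen in place of methoxy on this aromatic carbon of the five-membered ring gives a 1.5-fold higher number from compound 1 to compound 3 (0.19 log units; within the scatter), so the change leaves volume of distribution without a clear shift. In a physicochemical assay for solubility, read by HPLC, in phosphate buffer, with a stated time of 24 h, at pH 6.5 (on this read-out lower numbers stand for lower solubility and higher numbers for higher solubility), compound 1 gives < 1 ug/mL, which is a limit of the assay and not a number. In the physicochemical assay, compound 3 gives 15 ug/mL, so at this place the change separates the two compounds clearly on solubility, though not on volume of distribution: the measured solubility of compound 1, < 1 ug/mL, and of compound 3, 15 ug/mL, an at least 15-fold higher number (1.17 log units; beyond the scatter)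

As far as these compounds go, whether an amine or a nitrile on this carbon would read more like hydrogen or more like methoxy remains open for both read-outs. Also open, from the compounds shown here alone, is whether an ethoxy group, with its longer chain, would give the same solubility as methoxy.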